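The source may report more compounds than this note shows. Statements on the series, on what has been measured and on what is new or still open speak of the compounds shown alone.

Compound 1 `Nc1nc(SCc2ccccc2)[nH]c(=O)c1N(Cc1ccccc1)Cc1ccccc1` and compound 3 `CC(=O)Nc1nc(SCc2ccccc2)[nH]c(=O)c1N(Cc1ccccc1)Cc1ccccc1` share one core, while compound 2 `CCCSc1nc(N)c(N(CCC)CCC)c(=O)[nH]1` and the not yet measured compound 4 `CCCSc1nc(NC(C)=O)c(N(CCC)CCC)c(=O)[nH]1` share another; how the two cores differ from each other is not broken down here. In a functional assay on cardiac atrium (Cavia porcellus) (on this read-out lower numbers stand for an effect already at smaller amounts and higher numbers for an effect only at larger amounts of compound), compound 1 gives 3160 nM, compound 2 gives 1960 nM and compound 3 gives 1410 nM. The change from compound 1 to compound 3 is acetyl in place of hydrogen on a nitrogen on an aromatic ring, and it brought a 2.2-fold lower number from compound 1 to compound 3 (0.35 log units; beyond the scatter). Compound 4 arises from compound 2 by the same change, (acetyl in place of hydrogen on a nitrogen on an aromatic ring), at a place described in the same words. Because compound 3 showed a 2.2-fold lower number from compound 1 to compound 3 (0.35 log units; beyond the scatter), a step of about a 2.2-fold lower number from compound 2 to compound 4 (0.34 log units; beyond the scatter) is expected in this assay when the change is carried over to compound 2. On that basis compound 4 is estimated at 900 nM, with a likely range from 400 nM to 2000 nM.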

Compound 4, half-maximal effective concentration: 280 nM
The estimate for compound 4 lay 3.2-fold (0.51 log units) above the measured number; the measured number lies below the stated range.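

In this assay putting acetyl in place of hydrogen, the change from amino to acetamido, brings a 7.0-fold lower number from compound 2 to compound 4 (0.85 log units; beyond the scatter) and so goes the same way as on the other core, but not by the same amount: the same change on two cores in this assay, a 2.2-fold lower number (0.35 log units; beyond the scatter) from compound 1 to compound 3 and a 7.0-fold lower number (0.85 log units; beyond the scatter) from compound 2 to compound 4, 3.1-fold (0.49 log units) apart, beyond the scatter of two such steps. The direction therefore carried over between these two cores, while the size of the step on one core did not give its size on the other. Two pairs do not show why the sizes differ, and the step cannot be taken as a fixed amount for any further core.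

The compounds shown leave open whether a propionyl or a methanesulfonyl group in place of acetyl would go the same way on both cores. They also leave open how the step runs on a core carrying butyl chains in place of the propyl or benzyl groups.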